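This account rests on a few compounds, and the source may have more. Where it says the series, first, only, none or still open, it means among the compounds named here.

Working notes on the series. Compound 1 `Cc1nc(-c2ccc(C(F)(F)F)cc2)sc1CNc1ccc(OCC(=O)O)cc1` is measured in a functional assay on CHO cells for agonist activity at Free fatty acid receptor 1 (Homo sapiens) (a higher number here means that more compound is needed for the effect, a lower number that less compound is needed), at 288 nM, which is the highest of the two plain numbers available here. Compound 3 `NC(=O)CCc1ccc(NCc2cccc(Oc3ccccc3)c2)cc1` gives 51.3 nM in this assay, a lower number than compound 1 and beyond the scatter. Compound 2 `O=C(O)[C@H]1C[C@@H]1c1ccc(NCc2cccc(Oc3ccccc3)c2)cc1` has been run repeatedly, giving 12.3 nM; 13.5 nM (2 entries) in this assay; the repeats agree, as the several entries show (the several entries of compound 2 in this assay, 12.3 nM; 13.5 nM (2 entries)). Compounds 2 and 3 share a different core from compound 1, so their numbers are reported beside it without a counted step.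

Compound 4 `Cc1nc(-c2ccc(C(F)(F)F)cc2)sc1CNc1ccc([C@H]2C[C@@H]2C(=O)N(C)C)cc1` keeps the core of compound 1 and differs in one place: 2-(dimethylcarbamoyl)cyclopropyl in place of carboxymethoxy on an aromatic carbon, para to a large group. For the measured compounds named here, no step between measured compounds covers this change. Compound 4 is expected to stay near compound 1, with the step from compound 1 to compound 4 estimated at a 1.6-fold higher number from compound 1 to compound 4 (0.19 log units; within the scatter), leaning to a higher number. Compound 4 is estimated at 450 nM in this assay, within a range of 100 nM to 2500 nM.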

Compound 4, half-maximal effective concentration: 66.1 nM
Estimate against measurement, compound 4: 6.8-fold (0.83 log units) above; measured number below the stated range.
By their numbers in this assay, from the lowest: compounds 3 and 4 (each within the scatter of the next); then compound 1.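

In this assay, the aromatic carbon para to a large group on the core of compound 1 accepts a substantial change, with a 4.4-fold lower number from compound 1 to compound 4 (0.64 log units; beyond the scatter). On this core, therefore, the number does not depend on keeping carboxymethoxy at this position: 2-(dimethylcarbamoyl)cyclopropyl, with no hydrogen-bond donor and without the carboxylic acid, gives a lower number rather than a loss. Nothing in the data on hand explains this step.

The three-membered ring and the dimethylcarbamoyl group enter together, so the share of the step belonging to each remains unresolved. A 2-carboxycyclopropyl group or a simple dimethylcarbamoylmethyl chain at this position on the same core would separate the two, and the opposite stereoisomer of the cyclopropyl group remains an open comparison as well.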